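This account rests on a few compounds, and the source may have more. Where it says the series, first, only, none or still open, it means among the compounds named here.

Values so far in a functional assay on MIA PaCa-2 cells (Homo sapiens) for cytotoxicity, read by MTT assay, with a stated time of 72 h; on this read-out lower numbers stand for stronger inhibition and higher numbers for weaker inhibition

compound 1 `COC1=CC(=O)c2c(COc3ccccc3)c(C)n(C)c2C1=O` gives 409 nM
compound 2 `COC1=CC(=O)c2c(COc3ccc([N+](=O)[O-])cc3F)c(C)n(C)c2C1=O` gives 417 nM
compound 3 `COC1=CC(=O)c2c(COc3ccc(C#N)cc3)c(C)n(C)c2C1=O` gives 192 nM

Of these three, compound 3 has the lowest number (192 nM), which means the strongest inhibition so far. Compound 4 `COC1=CC(=O)c2c(COc3ccc(F)cc3F)c(C)n(C)c2C1=O` is still unmeasured. It differs from compound 3 by 2,4-difluorophenyl in place of 4-cyanophenyl on an oxygen on a saturated carbon.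

For the measured compounds named here, only one measured step bears directly on this change. The step of a 2.1-fold lower number from compound 1 to compound 3 (0.33 log units; beyond the scatter) came with cyano in place of hydrogen on an aromatic carbon, and it is modest in size. Compound 4 gives up that cyano, so much of this gain may be lost. Compound 1 gives 409 nM, and compound 2, which has no cyano but does carry a fluorine on its aromatic ring, gives a similar number, 417 nM. Going by the values given here, no measured compound has the two fluorines of compound 4, so this comparison is only a guide.

In this assay a modest move toward a higher number is therefore expected, with the estimate being a 1.8-fold higher number from compound 3 to compound 4 (0.25 log units; within the scatter) in size. For compound 4 the estimated value is 340 nM with an expected range from 170 nM to 650 nM in this assay.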

Compound 4, half-maximal inhibitory concentration: 75 nM
Estimate against measurement, compound 4: 4.5-fold (0.66 log units) above; the measured number lies below the stated range.
By their numbers in this assay, from the lowest: compound 4; then compound 3; then compounds 1 and 2 (each within the scatter of the next).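

In this assay, the nitrile of compound 3 turns out not to be needed for a low number, since 2,4-difluorophenyl in place of 4-cyanophenyl on this oxygen gives a 2.6-fold lower number from compound 3 to compound 4 (0.41 log units; beyond the scatter). The same ring also outperforms the two other groups tested here: 2,4-difluorophenyl in place of phenyl gives a 5.5-fold lower number from compound 1 to compound 4 (0.74 log units; beyond the scatter), and fluoro in place of nitro on an aromatic carbon gives a 5.6-fold lower number from compound 2 to compound 4 (0.75 log units; beyond the scatter), which makes compound 4, at 75 nM, the strongest inhibitor of the four. So the group on this oxygen can lower the number through a plain fluorine substitution, and nothing here explains why this ring does better than the others.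

On these data alone, it remains open whether a single fluorine on an otherwise bare phenyl ring would do as well as the pair, or whether both are required. As far as these compounds go, it is equally open whether chlorine, a methoxy group or an amine on this ring would move the number the same way, and whether a longer chain between the ring and the shared core would keep the gain.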